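A few compounds are considered here, and "the series" means these few. Any claim that something is new, unique, unknown or untested is made for them only; others in the source may bear on it.

For the measured compounds named here, compound 2 `CC(C)(C)c1ccc(Cn2cc(C(N)=O)c3c(N)ncnc32)cc1` gives 900 nM in a functional assay on KB cells (Homo sapiens) for cytotoxicity (a higher number here means a weaker inhibitor, a lower number a stronger inhibitor), the lowest of the two numbers so far; compound 1 `NC(=O)c1cn(Cc2ccccc2)c2ncnc(N)c12` gives 75000 nM. Compound 3 `COc1ccc(Cn2cc(C(N)=O)c3c(N)ncnc32)cc1` differs from compound 2 by methoxy in place of tert-butyl on an aromatic carbon. Going by the values given here, the one measured step that bears on this place is an 83-fold lower number from compound 1 to compound 2 (1.92 log units; beyond the scatter), which shows that changing the group at this carbon can move the number a great deal. Since tert-butyl is removed again and a different group takes its place, a partial reversal of that gain is expected: an 8.9-fold higher number from compound 2 to compound 3 (0.95 log units; beyond the scatter). Compound 3 is estimated at 8000 nM, with a range from 2000 nM to 30000 nM.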

Compound 3, half-maximal inhibitory concentration: 47000 nM
Compound 3: middle estimate off by 5.9-fold (0.77 log units), on the low side; the whole stated range lies below it.
By their numbers in this assay, from the lowest: compound 2; then compounds 3 and 1 (each within the scatter of the next).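

Moving from tert-butyl to methoxy gives a 52-fold higher number from compound 2 to compound 3 (1.72 log units; beyond the scatter) in this assay, so the gain seen with tert-butyl does not carry over to methoxy. The step of a 1.6-fold lower number from compound 1 to compound 3 (0.20 log units; within the scatter) lies within the scatter, which places methoxy level with plain hydrogen at this carbon. Having a group here is therefore not enough, and among these three compounds only tert-butyl stands apart. Nothing available explains this difference. On these data alone, it remains open how an isopropyl, a chlorine, an amine or a longer chain at this carbon would compare, and whether any group would match tert-butyl.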